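A few compounds are considered here, and "the series" means these few. Any claim that something is new, unique, unknown or untested is made for them only; others in the source may bear on it.

Measured in a physicochemical assay for lipophilicity; a higher number here means a more lipophilic compound, a lower number a more polar compound:
compound 1, `CC(/C=C/CC(C)CCCC(C)C)=C\C(=O)OCC(C)C`: 7.69
compound 2, `CCSC(=O)/C=C(C)/C=C/CC(C)CCCC(C)(C)OC`: 6.78
compound 3, `C=CCSC(=O)/C=C(C)/C=C/CC(C)CCCC(C)(C)OC`: 6.77

Compound 1 stands highest of the three in this assay; compound 2 and compound 3 both lie below it by more than the usual scatter, while the values of compound 2 and compound 3 sit within the scatter of each other. Among the measured compounds shown here, the only single-point step among the measured compounds is a number 0.01 log units lower from compound 2 to compound 3 (within the scatter), a change that leaves the value essentially where it was.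

The next compound, compound 4, `CC(/C=C/CC(C)CCCC(C)C)=C\C(=O)N(C)C`, follows from compound 1 by one change: dimethylamino in place of isobutoxy on a carbonyl carbon. For the measured compounds named here, no measured step concerns this kind of change; the one step available touches a chain carbon bound to sulfur and not the carbonyl carbon, so it gives no direct guide. The expectation therefore rests on the change itself: isobutoxycarbonyl gives way to dimethylcarbamoyl, with the heavy atoms counted in the difference lost. A downward step in this assay, beyond the scatter, is expected; its size is estimated as a number 1.99 log units lower from compound 1 to compound 4 (beyond the scatter). For compound 4 the value expected is 5.7, within a range from 4.9 to 6.5.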

Compound 4, partition coefficient: 4.94
For compound 4 the middle estimate is 0.76 log units above the measured one, and the stated range covers the measured number.
By their numbers in this assay, from the lowest: compound 4; then compounds 3 and 2 (each within the scatter of the next); then compound 1.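

In this assay, this position on the carbonyl carbon turns out to be sensitive: dimethylamino in place of isobutoxy gives a number 2.75 log units lower from compound 1 to compound 4 (beyond the scatter). Among the compounds shown here, this is the first step that lies beyond the scatter, whereas the only earlier step, at a chain carbon bound to a sulfur and so at a different place, stayed within it as a number 0.01 log units lower from compound 2 to compound 3 (within the scatter). Nothing on hand explains the size of the new step.

This single change swaps isobutoxy, with its oxygen and larger heavy-atom count, for dimethylamino, with its nitrogen and smaller count, so the compounds shown leave open how much of the step goes with the size of the group and how much with the atom bound to the carbonyl carbon; methoxy or diethylamino on that carbon would separate the two. Also open, from the compounds shown here alone, is how a carboxylic acid or a monomethylamino group at the same carbon would read in this assay, and whether the step would keep its size on the core of compound 2.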